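Swapping the Side Ring: From Thiophene to Dihydroxyphenyl

The compounds below may be only part of what the source reports. "The series", "measured", "known", "first", "only" and "open" are said of these compounds alone.

Three compounds share one core and differ only in the ring attached to it. Compound 1 `CCOC(=O)c1cnn(-c2nc(-c3ccccc3F)c(C#N)c(=O)n2C)c1N` gives 86 ug/mL in a functional assay, with a stated time of 10 min; on this read-out lower numbers stand for stronger inhibition and higher numbers for weaker inhibition. Compound 2 `CCOC(=O)c1cnn(-c2nc(-c3ccco3)c(C#N)c(=O)n2C)c1N` gives 104 ug/mL, and compound 3 `CCOC(=O)c1cnn(-c2nc(-c3cccs3)c(C#N)c(=O)n2C)c1N` gives 109 ug/mL; the step of a 1.3-fold higher number from compound 1 to compound 3 (0.10 log units; within the scatter) and the step of a 1.0-fold higher number from compound 2 to compound 3 (0.02 log units; within the scatter) both lie within the scatter, so compound 3 sits level with the other two. Compound 4 `CCOC(=O)c1cnn(-c2nc(-c3cccc(O)c3O)c(C#N)c(=O)n2C)c1N` carries the change (2,3-dihydroxyphenyl in place of thiophen-2-yl on an aromatic carbon). For the measured compounds named here, the steps that bear on this swap, a 1.2-fold higher number from compound 1 to compound 2 (0.08 log units; within the scatter) and a 1.3-fold higher number from compound 1 to compound 3 (0.10 log units; within the scatter), were both within the scatter, so no shift beyond the scatter is expected for compound 4, a 1.1-fold lower number from compound 3 to compound 4 (0.04 log units; within the scatter). Compound 4 is therefore estimated at 100 ug/mL, with a range from 50 ug/mL to 200 ug/mL.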

Compound 4, half-maximal inhibitory concentration: 53 ug/mL
Beside the measured number, compound 4's estimate is 1.9-fold (0.28 log units) above it; measured number inside the range.
By their numbers in this assay, from the lowest: compounds 4, 1, 2 and 3 (each within the scatter of the next, the first and the last beyond it).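

In this assay, for the compounds shown here, the 2,3-dihydroxyphenyl group gives a 2.1-fold lower number from compound 3 to compound 4 (0.31 log units; beyond the scatter) and so provides the first step at this position to clear the scatter, though only a modest one. By contrast, a 2.0-fold lower number from compound 2 to compound 4 (0.29 log units; within the scatter) and a 1.6-fold lower number from compound 1 to compound 4 (0.21 log units; within the scatter) remain within the scatter, so compound 4 stands apart only from compound 3. On these data alone, whether a phenyl ring with a single hydroxyl group, or with an amine or a carboxylic acid, would behave like compound 4 stays open. Nothing measured here explains the step.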